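The source may report more compounds than this note shows. Statements on the series, on what has been measured and on what is new or still open speak of the compounds shown alone.

In an ADME assay on the whole organism for cytotoxicity, with Artemia salina as the target, with a stated time of 24 h (a higher number here means that more compound is needed for the effect, a lower number that less compound is needed), three compounds have been measured so far:
compound 1 `COc1ccc(/C=C/C(=O)c2ccccc2NC(=O)NS(=O)(=O)c2ccc(C)cc2)cc1` gives 28.1 ug/mL;
compound 2 `CCc1cc(/C=C/C(=O)c2ccccc2NC(=O)NS(=O)(=O)c2ccc(C)cc2)cc(OC)c1OC` gives 19.2 ug/mL;
compound 3 `Cc1ccc(S(=O)(=O)NC(=O)Nc2ccccc2C(=O)/C=C/C=C/c2ccccc2)cc1` gives 18.2 ug/mL.

Compound 1 stands at the upper end of these three numbers, yet its steps to the other two, a 1.5-fold lower number from compound 1 to compound 2 (0.17 log units; within the scatter) and a 1.5-fold lower number from compound 1 to compound 3 (0.19 log units; within the scatter), both lie within the scatter, as does a 1.1-fold lower number from compound 2 to compound 3 (0.02 log units; within the scatter). Compound 4 `Cc1ccc(S(=O)(=O)NC(=O)Nc2ccccc2C(=O)/C=C/c2cccnc2)cc1` has not yet been measured. It differs from compound 1 at one place: pyridin-3-yl in place of 4-methoxyphenyl on a double-bonded chain carbon bound to a double-bonded chain carbon. The two measured steps from compound 1 are swaps at that same place, and each moved the number only within the scatter. A step beyond the scatter in this assay is therefore not expected from compound 1 to compound 4 in either direction. Compound 4 is estimated at 23 ug/mL, within a range of 10 ug/mL to 50 ug/mL, so the expected step is a 1.2-fold lower number from compound 1 to compound 4 (0.09 log units; within the scatter).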

Compound 4, concentration for half-maximal effect: 14.1 ug/mL
Beside the measured number, compound 4's estimate is 1.6-fold (0.21 log units) above it, within the range that was stated.
By their numbers in this assay, from the lowest: compounds 4, 3, 2 and 1 (each within the scatter of the next).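

In this assay the place on the double-bonded chain carbon also accepts pyridin-3-yl, a ring with a hetero atom, and the largest step yet at this place, a 2.0-fold lower number from compound 1 to compound 4 (0.30 log units; within the scatter), still stays within the scatter, as do a 1.3-fold lower number from compound 3 to compound 4 (0.11 log units; within the scatter) and a 1.4-fold lower number from compound 2 to compound 4 (0.13 log units; within the scatter). All four groups shown at this place thus give numbers within the scatter of one another. Nothing measured here accounts for these small steps. As far as these compounds go, whether a carboxylic acid or an amine at this place would give a step beyond the scatter remains open.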